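A few compounds are considered here, and "the series" means these few. Any claim that something is new, unique, unknown or untested is made for them only; others in the source may bear on it.

Measured so far in an ADME assay on HEK293 cells (Homo sapiens) for cytotoxicity, read by resazurin assay, with a stated time of 48 h; a higher number here means that more compound is tolerated, a lower number that less compound is tolerated:
- compound 1 `Cc1ccc(S(=O)(=O)Nc2ccc3oc(-c4ccccc4)nc3c2)cc1`: 75000 nM
- compound 2 `O=S(=O)(Nc1ccc2oc(-c3ccccc3)nc2c1)c1ccc(F)c(C(F)(F)F)c1`: > 100000 nM

Of the compounds shown here, two have been tested for how much of them cultured human kidney cells tolerate. Compound 1 gives 75000 nM in this assay. Compound 2 is reported only as a limit of the assay, > 100000 nM, not as a number. For the measured compounds named here, compound 1 therefore stands as the only actual number in the set; the other result is the limit described by the limit of > 100000 nM in this assay, at which 1 of the 2 values shown sits, and the two cannot be ranked against each other.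

Compound 3 `O=S(=O)(Nc1ccc2oc(-c3ccccc3)nc2c1)c1ccccc1O` has not yet been measured. It is built from compound 1 by a single change: 2-hydroxyphenyl in place of 4-methylphenyl on a sulfonyl sulfur. Going by the values given here, no pair of measured compounds shows what such a swap does in this assay, so there is no measured step to lean on. The step from compound 1 to compound 3 is expected to be small, a 1.1-fold lower number from compound 1 to compound 3 (0.03 log units; within the scatter), within the usual scatter rather than beyond it. Compound 3 is accordingly estimated to give 70000 nM in this assay, with a likely range from 25000 nM to 150000 nM.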

Compound 3, half-maximal cytotoxic concentration: 33000 nM
Estimate against measurement, compound 3: 2.1-fold (0.33 log units) above; the measured number falls inside the stated range.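

In this assay, for the compounds shown here, the swap of 2-hydroxyphenyl for 4-methylphenyl on a sulfonyl sulfur supplies the first measured step, a 2.3-fold lower number from compound 1 to compound 3 (0.36 log units; beyond the scatter), which shows that changing this group alone, with the rest of the molecule held constant, can shift how much compound the cells tolerate. The two groups have the same heavy-atom count and the same kind of ring, and the computed differences are that 2-hydroxyphenyl brings an oxygen, a hydrogen-bond donor and a hydrogen-bond acceptor, while 4-methylphenyl has none of these, although one step cannot show which difference matters, if any. Compound 2, which carries a third group at this place, adds no second step, since its result is a limit of the assay and not a number: the limit of > 100000 nM in this assay, at which 1 of the 3 values shown sits.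

As far as these compounds go, whether the hydroxyl itself drives the step remains open, and a methoxy, an amine or a carboxylic acid in its stead, or a plain phenyl, would help separate the effect of adding the hydroxyl from that of losing the methyl. It is also unknown whether this step would hold with a different core, since it rests on a single pair of compounds.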